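This account rests on a few compounds, and the source may have more. Where it says the series, first, only, none or still open, it means among the compounds named here.

Of the compounds shown here, three of a shared core have been tested in a functional assay on HepG2 cells (Homo sapiens) for cytotoxicity, read by MTT assay, with a stated time of 48 h; a lower number here means a stronger inhibitor, a higher number a weaker inhibitor. Compound 1, `CCCCCCCCCCCCCCCCCCNC(=O)[C@@H](N)[C@@H](C)O`, gives 44500 nM. Compound 2, `CCCCCCCCNC(=O)[C@@H](NC(=O)c1ccco1)[C@@H](C)O`, gives 192000 nM. Compound 3, `CCCCCCCCNC(=O)[C@@H](NC(=O)c1nccc2ccccc12)[C@@H](C)O`, gives 88200 nM. Among these three numbers, compound 2 stands highest: the gaps to compound 3 and to compound 1 both lie beyond the usual scatter, so compound 2 is the weakest inhibitor of the three in this assay.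

Compound 4, `C/C=C/C=C/C(=O)N[C@H](C(=O)NCCCCCCCC)[C@@H](C)O`, has not yet been measured in this assay. It differs from compound 2 in one place: penta-1,3-dien-1-yl in place of furan-2-yl on a carbonyl carbon. For the measured compounds named here, no measured pair shows the effect of such a change on this core, so the direction of the step is open. Since the three known values all sit close together in a weak range, compound 4 is expected to land near compound 2, with a step of a 1.3-fold lower number from compound 2 to compound 4 (0.11 log units; within the scatter) that need not exceed the scatter. Compound 4 is thus estimated at 150000 nM, with a range from 60000 nM to 400000 nM.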

Compound 4, half-maximal inhibitory concentration: 102000 nM
Estimate against measurement, compound 4: 1.5-fold (0.17 log units) above; the range from low to high includes it.
By their numbers in this assay, from the lowest: compounds 1, 3, 4 and 2 (each within the scatter of the next, the first and the last beyond it).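

For the compounds shown here, putting penta-1,3-dien-1-yl in place of furan-2-yl on a carbonyl carbon gives a 1.9-fold lower number from compound 2 to compound 4 (0.27 log units; within the scatter) in this assay, the first measured step at this position on the shared core. The two groups have the same number of heavy atoms, but one is a five-membered aromatic ring with a hydrogen-bond acceptor and the other an open chain with two double bonds and no acceptor, and this assay does not separate the two compounds. No measurement shown here gives a reason for this result.

Going by these compounds, whether any group at this position can move the number beyond the scatter stays open. A saturated chain such as pentyl, or a group carrying an amine or a carboxylic acid, on the same carbonyl carbon would test this.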